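The compounds below may be only part of what the source reports. "The series", "measured", "known", "first", "only" and "open" are said of these compounds alone.

Measured so far in an assay (Cavia porcellus) for displacement of a labelled ligand from Sigma non-opioid intracellular receptor 1 (Homo sapiens); a lower number here means a stronger inhibitor, a higher number a weaker inhibitor:
Compound 2 `NC(CCCN1CCN(c2ncc(F)cn2)CC1)C1CCCCC1` gives 52 nM.
Compound 1 `O=C(NC(CCCN1CCN(c2ncc(F)cn2)CC1)c1ccc(F)cc1)c1ccc(F)cc1` gives > 100 nM, which is a limit of the assay and not a number.

For the measured compounds named here, compound 2 is thus the only compound with a measured number in this assay; the other entry is the limit of > 100 nM in this assay, at which 1 of the 2 values shown sits, so nothing can be said about how far apart the two truly lie. Going by the values given here, compound 1 and compound 2 differ in more than one place, and no single step between them can be traced.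

The next compound, compound 3 `O=C(NC(CCCN1CCN(c2ncc(F)cn2)CC1)C1CCCCC1)c1ccc(F)cc1`, has not yet been measured in this assay. It arises from compound 2 by a single change: (4-fluorophenyl)carbonyl in place of hydrogen on an amine nitrogen. Compound 1 carries this same ((4-fluorophenyl)carbonyl)amino group and sits at the limit, whereas compound 2 with the free amino group gives a number; beyond that, nothing is known about how this change acts on the shared core. The step from compound 2 to compound 3 is therefore expected to weaken binding, a 5.8-fold higher number from compound 2 to compound 3 (0.76 log units; beyond the scatter), with a real chance that only a limit is returned. For compound 3 the estimate is 300 nM, expected to fall between 60 nM and 2000 nM.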

Compound 3, half-maximal inhibitory concentration: > 2 nM
Compound 3: no number, only a limit; the forecaster's own chance of this, stated with the estimate: 50%; the middle value does not contradict the limit.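

In this assay compound 3 gives > 2 nM, which is a limit of the assay and not a number. For the compounds shown here, neither the step linking compound 2 to compound 3 nor the one linking compound 1 to compound 3 can be read. Still open, as far as these compounds go, is whether (4-fluorophenyl)carbonyl in place of hydrogen on the amine nitrogen strengthens or weakens binding, and by how much.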